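Replacing 2-amino-1,3-thiazol-5-yl with pyrimidin-5-yl

The compounds below may be only part of what the source reports. "The series", "measured", "known", "first", "only" and "open" are said of these compounds alone.

- compound 1 `OC(c1ccc(Cl)cc1)(c1ccc(Cl)cc1)c1cncnc1`: 47200 nM
- compound 2 `OC(c1ccc(Cl)cc1)(c1ccc(Br)cc1)c1cccnc1`: 57000 nM
- compound 3 `Nc1ncc(C(O)(c2ccc(Cl)cc2)c2cccnc2)s1`: 56000 nM

In an ADME assay on L6 cells (Rattus norvegicus) for cytotoxicity, read by resazurin assay, with a stated time of 72 h (on this read-out lower numbers stand for stronger inhibition and higher numbers for weaker inhibition), compound 3 gives 56000 nM, which lies within the usual scatter of compound 1 and compound 2, so these three values cannot be ranked. Compound 4 `OC(c1ccc(Cl)cc1)(c1cccnc1)c1cncnc1` differs from compound 3 by a single exchange: pyrimidin-5-yl in place of 2-amino-1,3-thiazol-5-yl on a saturated chain carbon bound to two aromatic carbons and an oxygen on a saturated carbon. Within the data shown here, only one measured step bears on this place: a 1.0-fold lower number from compound 2 to compound 3 (0.01 log units; within the scatter). That step also exchanges one aromatic group at this place, and it stays within the scatter. This exact exchange has not been measured, but no step beyond the scatter is expected in this assay. The expected change is a 1.2-fold higher number from compound 3 to compound 4 (0.06 log units; within the scatter). For compound 4 the estimate is 65000 nM, with an expected range from 30000 nM to 140000 nM.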

Compound 4, half-maximal inhibitory concentration: > 100000 nM
Compound 4: a limit, no number; the forecaster's own chance of this, stated with the estimate: 15%; middle value at least 1.5-fold (0.18 log units) away from the limit.
By their numbers in this assay, from the lowest: compounds 1, 3 and 2 (each within the scatter of the next). At a limit, above all of these: compound 4.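

In this assay compound 4 gives a limit and not a number: the limit of > 100000 nM in this assay, at which 1 of the 4 values shown sits.
Among these compounds, with pyridin-3-yl in place of 4-chlorophenyl, the data show an at least 2.1-fold higher number from compound 1 to compound 4 (0.32 log units; beyond the scatter) and this is the first step at this carbon to leave the scatter, so changing a group here can move the read-out. The other two steps, an at least 1.7-fold higher number from compound 3 to compound 4 (0.25 log units; that floor lies within the scatter) and an at least 1.7-fold higher number from compound 2 to compound 4 (0.24 log units; that floor lies within the scatter), have floors that stay inside the scatter, so neither exchange can yet be called a real rise.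

On these data alone, how far compound 4 lies past its limit stays open. So does whether an amine or a carboxylic acid at this place would give a lower number.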